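A few compounds are considered here, and "the series" means these few. Any claim that something is new, unique, unknown or untested is made for them only; others in the source may bear on it.

The series shares one core, seen in compound 1 `O=S(=O)(Nc1ccc(-c2nc3ccccc3o2)cc1)c1cccc(O)c1`. In an assay on isolated protein for inhibition of malate dehydrogenase, mitochondrial (Sus scrofa), with stated times of 45 min and 30 min (on this read-out higher numbers stand for weaker inhibition and lower numbers for stronger inhibition), compound 1 gives a limit of the assay, > 63000 nM. Compound 2 `O=S(=O)(Nc1ccc(-c2nc3ccccc3o2)cc1)c1ccc(F)c(C(F)(F)F)c1` in this assay also gives a limit, > 63000 nM. Compound 3 `O=S(=O)(Nc1ccc(-c2nc3ccccc3o2)cc1)c1ccccc1F` in this assay again gives a limit, > 63000 nM. The one step recorded among these, a step that the two limits leave unreadable from compound 1 to compound 3, cannot be read from the two limits it joins; the only evidence is that (the limit of > 63000 nM in this assay, at which 3 of the 3 values shown sit). Compound 4 `O=S(=O)(Nc1ccc(-c2nc3ccccc3o2)cc1)c1ccc(F)cc1` has the same atoms as compound 3, joined differently: 4-fluorophenyl in place of 2-fluorophenyl on a sulfonyl sulfur. Among the measured compounds shown here, no measured step bears on this change with a readable size, since the one recorded step and all three values stop at the limit. Nothing here points to inhibition appearing in this assay for compound 4, and compound 4 is therefore expected to give 100000 nM, within 40000 nM to 300000 nM, most likely reported only as a limit. The expected step from compound 3 to compound 4 is a step that the limit leaves unreadable from compound 3 to compound 4, no change beyond the scatter.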

Compound 4, half-maximal inhibitory concentration: > 63000 nM
Compound 4 was reported as a limit; the forecaster's own chance of this, stated with the estimate: 85%; the middle value is on the limit's open side.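

No step can be read from compound 4 to compound 1, compound 2 or compound 3, as each value is only a limit of the assay: the limit of > 63000 nM in this assay, at which 4 of the 4 values shown sit. The compounds shown leave open whether any group on the sulfonyl sulfur of the shared core gives a readable value in this assay.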